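Thiazolidinedione amides: benzothiazole in place of methylthiazole

This account rests on a few compounds, and the source may have more. Where it says the series, first, only, none or still open, it means among the compounds named here.

Compound 1: `Cc1cnc(NC(=O)COc2ccc(/C=C3\SC(=O)NC3=O)cc2)s1`; in a functional assay on KB cells (Homo sapiens) for cytotoxicity, read by sulforhodamine B assay, with a stated time of 48 h (a higher number here means a weaker inhibitor of growth, a lower number a stronger inhibitor of growth), compound 1 gives < 100000 nM, a limit of the assay.
Compound 2: `CCCCC1=NC2(CCCC2)C(=O)N1C(=O)COc1ccc(/C=C2/SC(=O)NC2=O)cc1`; in this assay compound 2 gives < 100000 nM, also a limit.

Compound 1 thus stands only at a limit, the same limit at which every value shown sits (the limit of < 100000 nM in this assay, at which 2 of the 2 values shown sit). Compound 3, `O=C(COc1ccc(/C=C2\SC(=O)NC2=O)cc1)Nc1nc2ccccc2s1`, differs from compound 1 by 1,3-benzothiazol-2-yl in place of 5-methyl-1,3-thiazol-2-yl on an amide-type nitrogen, in words 1,3-benzothiazol-2-yl in place of 5-methyl-1,3-thiazol-2-yl on an amide-type nitrogen. Among the measured compounds shown here, no measured step exists in this assay; no step beyond the scatter is expected, and the estimated step that the limit leaves unreadable from compound 1 to compound 3 is taken as small. Compound 3 is expected to give 60000 nM, between 15000 nM and 100000 nM, quite possibly again reported as a limit.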

Compound 3, concentration for total growth inhibition: < 100000 nM
Compound 3 gave a limit, no number; the forecaster's own chance of this, stated with the estimate: 70%; the middle value does not contradict the limit.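

No step from compound 1 to compound 3 can be read in this assay, because both compounds stand only at a limit: the limit of < 100000 nM in this assay, at which 3 of the 3 values shown sit.

The compounds shown leave open whether 1,3-benzothiazol-2-yl in place of 5-methyl-1,3-thiazol-2-yl on an amide-type nitrogen shifts growth inhibition in this assay at all.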